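Swapping a Basic Amine Tail for a Hydroxyl Tail

The compounds below may be only part of what the source reports. "The series", "measured", "known", "first", "only" and "open" are said of these compounds alone.

Among the compounds with values here, compound 2 `CCn1cc(C(CC)(CC)c2ccc(C#CC(O)(CC)CC)c(C)c2)cc1C(=O)NCCCN(C)C` is one of two compounds measured in an assay on cells for agonist activity at vitamin D3 receptor (Homo sapiens), read by microscopy; on this read-out lower numbers stand for an effect already at smaller amounts and higher numbers for an effect only at larger amounts of compound. Compound 2 gives 142 nM, the higher of the two numbers, while compound 1 `CCN(CC)CCNC(=O)c1ccc(C(CC)(CC)c2ccc(OCC(O)C(C)(C)C)c(C)c2)n1CC` gives 6.54 nM; the two compounds differ in several places at once, so the gap between them cannot be pinned to any single change.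

Compound 3 `CCn1cc(C(CC)(CC)c2ccc(C#CC(O)(CC)CC)c(C)c2)cc1C(=O)N[C@@H](C)CO` is built from compound 2 by one alteration on the amide side chain: 1-(hydroxymethyl)ethyl in place of 3-(dimethylamino)propyl on an amide-type nitrogen. Within the data shown here, no measured pair in this set shows this particular change, so there is no direct precedent to lean on. The change is confined to the amide tail and keeps the rest of the molecule intact, so a step in this assay of moderate size is expected, with a slight lean toward a lower number. The estimate for compound 3 in this assay is 100 nM, within a range of 25 nM to 400 nM, which corresponds to an expected step of a 1.4-fold lower number from compound 2 to compound 3 (0.15 log units; within the scatter).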

Compound 3, half-maximal effective concentration: 7.33 nM
For compound 3 the middle estimate is 14-fold (1.13 log units) above the measured one; measured number below the stated range.
By their numbers in this assay, from the lowest: compounds 1 and 3 (each within the scatter of the next); then compound 2.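

In this assay the amide tail proves to be a highly sensitive position: 1-(hydroxymethyl)ethyl in place of 3-(dimethylamino)propyl on the amide-type nitrogen gives a 19-fold lower number from compound 2 to compound 3 (1.29 log units; beyond the scatter) with the rest of the molecule unchanged. Unlike the gap between compound 1 and compound 2, this step can be tied to a single place in the molecule. Nothing available here explains why the number drops so far.

The swap still alters several things together, as the dimethylamino end goes, a hydroxyl arrives, the chain changes and a defined stereocentre appears, so this one pair cannot show which of these matters. Also open, as far as these compounds go, is how the opposite stereoisomer of 1-(hydroxymethyl)ethyl, a straight 2-hydroxyethyl chain or a 3-hydroxypropyl chain would behave on this nitrogen.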